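This account rests on a few compounds, and the source may have more. Where it says the series, first, only, none or still open, it means among the compounds named here.

Compound 2 `FC(F)(F)c1ccc2[nH]c(-c3ccc(-c4c[nH]nc4C(F)(F)F)cc3)nc2c1` gives 1200 nM in a functional assay for antagonist activity at Neuropeptides B/W receptor type 1 (Homo sapiens), read by cAMP accumulation; a lower number here means a stronger inhibitor, a higher number a weaker inhibitor. For the measured compounds named here, the only other measured compound, compound 1 `NCc1ccc(-c2ccc(-c3nc4cc(C(F)(F)F)ccc4[nH]3)cc2)cc1`, gives 720 nM, and the step of a 1.7-fold higher number from compound 1 to compound 2 (0.22 log units; within the scatter) lies within the scatter, so the two numbers cannot be told apart. Compound 3 `FC(F)(F)c1ccc2[nH]c(-c3ccc(-c4ccoc4)cc3)nc2c1` differs from compound 2 by furan-3-yl in place of 3-(trifluoromethyl)-1H-pyrazol-4-yl on an aromatic carbon. Going by the values given here, the one measured step changed the group at this same place and stayed within the scatter, so it bears on this change only loosely. The expected step of a 1.3-fold higher number from compound 2 to compound 3 (0.10 log units; within the scatter) is therefore small, with no clear direction. For compound 3 the estimate in this assay is 1500 nM, within a range from 600 nM to 4000 nM.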

Compound 3, half-maximal inhibitory concentration: 1190 nM
Compound 3: the middle estimate sits 1.3-fold (0.10 log units) above what was measured, and the stated range covers the measured number.
By their numbers in this assay, from the lowest: compounds 1, 3 and 2 (each within the scatter of the next).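

In this assay, furan-3-yl, with 5 heavy atoms and 0 hydrogen-bond donors, replaces the 3-(trifluoromethyl)-1H-pyrazol-4-yl, with 9 heavy atoms and 1 hydrogen-bond donor, and the result is a 1.0-fold lower number from compound 2 to compound 3 (0.00 log units; within the scatter) for this pair. Set against the 4-(aminomethyl)phenyl, furan-3-yl gives a 1.7-fold higher number from compound 1 to compound 3 (0.22 log units; within the scatter), so all three groups at this place, para to a large group, cannot be told apart. Nothing measured here offers an explanation for this.

On these data alone, whether a carboxylic acid or a longer alkyl chain at this place would separate from these three remains open. So does whether any group here could give a number clearly beyond the scatter.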